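Aryl-to-pyridyl Swap on the Aniline Nitrogen

The source may hold more compounds than are shown below. What is called first, only, known or untested is meant among the compounds shown, and "the series" means these compounds.

Compound 1 `C=CC(=O)Nc1cccc(Oc2nc(Nc3cccc(OC)c3)nc3ccsc23)c1` gives 4340 nM in a functional assay on A549 cells (Homo sapiens) for inhibition, read by MTT assay, with a stated time of 72 h; a lower number here means a stronger inhibitor, a higher number a weaker inhibitor.
Compound 2 `C/C=C/C(=O)Nc1cccc(Oc2nc(Nc3cccc(OC)c3)nc3ccsc23)c1` gives 10500 nM in this assay.
Compound 3 `COc1cccc(Nc2nc(Oc3cccc(NC(=O)/C=C/C(C)C)c3)c3sccc3n2)c1` gives 37100 nM in this assay.

Compound 3 gives the highest number of the three: an 8.5-fold higher number from compound 1 to compound 3 (0.93 log units; beyond the scatter) and a 3.5-fold higher number from compound 2 to compound 3 (0.55 log units; beyond the scatter). Compound 4 `COc1ccc(Nc2nc(Oc3cccc(NC(=O)/C=C/C(C)C)c3)c3sccc3n2)cn1` differs from it by 6-methoxypyridin-3-yl in place of 3-methoxyphenyl on a nitrogen on an aromatic ring. Going by the values given here, none of the measured steps touches this part of the molecule; the steps of a 2.4-fold higher number from compound 1 to compound 2 (0.38 log units; beyond the scatter) and a 3.5-fold higher number from compound 2 to compound 3 (0.55 log units; beyond the scatter) alter only the chain on the carbonyl carbon, so no measured step bears on the change from compound 3 to compound 4. With nothing pointing in either direction, the step is expected to remain within the scatter. Compound 4 is therefore estimated at 30000 nM, with a range from 10000 nM to 100000 nM, meaning an expected step of a 1.2-fold lower number from compound 3 to compound 4 (0.09 log units; within the scatter).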

Compound 4, half-maximal inhibitory concentration: > 50000 nM
Compound 4 was reported as a limit (the forecaster's own chance of this, stated with the estimate: 20%); middle value at least 1.6-fold (0.22 log units) away from the limit.
By their numbers in this assay, from the lowest: compound 1; then compound 2; then compound 3. At a limit, above all of these: compound 4.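

In this assay, 6-methoxypyridin-3-yl in place of 3-methoxyphenyl, the only change shown outside the chain on the carbonyl carbon, gives an at least 1.3-fold higher number from compound 3 to compound 4 (0.12 log units; that floor lies within the scatter). Compound 4 gives only a limit, > 50000 nM, and not a number. This change at this position therefore brings no lower number, but its true size stays unknown, since only a floor can be read: the limit of > 50000 nM in this assay, at which 1 of the 4 values shown sits.

On these data alone, whether the same swap would act alike with the vinyl chain of compound 1 remains open. So does the effect of an amine or a fluorine in place of the methoxy group.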